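The compounds below may be only part of what the source reports. "The series", "measured", "known", "first", "only" and "open" are said of these compounds alone.

Measured in a functional assay for agonist activity at Free fatty acid receptor 1 (Homo sapiens), read by FLIPR, in the presence of a further agent that is not named here; on this read-out higher numbers stand for an effect only at larger amounts of compound and lower numbers for an effect already at smaller amounts:
compound 1 `O=C1NC(=O)C(Cc2ccc(Sc3ccccc3)cc2)S1` gives 5060 nM
compound 2 `O=C1NC(=O)C(Cc2ccc(Oc3ccc(Cl)cc3)cc2)S1` gives 240 nM
compound 3 `Cc1cc(Oc2ccc(C(F)(F)F)cc2Cl)ccc1CC1SC(=O)NC1=O` gives 18 nM

Compound 2 stands second highest of the three numbers in this assay: compound 3 lies lower by a gap beyond the scatter, compound 1 higher by a gap beyond the scatter. The next compound to be run is compound 4 `Cc1ccc(Oc2ccc(CC3SC(=O)NC3=O)cc2)cc1`. Against compound 2 the change is methyl in place of chloro on an aromatic carbon, the group sitting on an aromatic carbon of a six-membered aromatic ring of carbon only, para to a large group. For the measured compounds named here, no measured pair shows this change, so the step from compound 2 to compound 4 in this assay is expected to be small, at most a modest move toward higher numbers, possibly none beyond the scatter, as a 1.5-fold higher number from compound 2 to compound 4 (0.16 log units; within the scatter). For compound 4 the expected value in this assay is 350 nM, within 120 nM to 1000 nM.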

Compound 4, half-maximal effective concentration: 547 nM
Beside the measured number, compound 4's estimate is 1.6-fold (0.19 log units) below it; the measured number falls inside the stated range.
By their numbers in this assay, from the lowest: compound 3; then compound 2; then compound 4; then compound 1.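

In this assay, for the compounds shown here, the swap of 4-chlorophenyl for 4-methylphenyl gives a 2.3-fold higher number from compound 2 to compound 4 (0.36 log units; beyond the scatter) and so provides the first single-place comparison. At this place, para to a large group, chloro and methyl are therefore not interchangeable, with the lower number on the chloro side, though this rests on one pair only. No measurement at hand accounts for the step.

As far as these compounds go, whether methoxy, fluoro or a nitrile at this place would give a lower or higher number remains open. Compound 3 differs from compound 2 in more than one place, so its number cannot be assigned to any single group.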